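A Fluorine Added to a Weakly Cytotoxic Compound

The source may report more compounds than this note shows. Statements on the series, on what has been measured and on what is new or still open speak of the compounds shown alone.

In a functional assay on A549 cells (Homo sapiens) for cytotoxicity, read by MTT assay, with a stated time of 72 h (on this read-out higher numbers stand for weaker inhibition and lower numbers for stronger inhibition), compound 1 `O=C(Nc1ccc(Oc2ccnc3[nH]ccc23)c(F)c1)c1nn(-c2ccc(Br)cc2F)ccc1=O` gives 55700 nM, a weak effect. Compound 2 `Cn1ccc2c(Oc3ccc(NC(=O)c4nn(-c5ccc(Br)cc5)ccc4=O)cc3F)ccnc21` gives only a limit of this assay, > 60000 nM, so no exact number is known for it. Among the two numbers shown, compound 2 therefore sits at the limit rather than at a measured value (the limit of > 60000 nM in this assay, at which 1 of the 2 values shown sits).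

Compound 3 `Cn1ccc2c(Oc3ccc(NC(=O)c4nn(-c5ccc(Br)cc5F)ccc4=O)cc3F)ccnc21` is compound 2 changed in one place: fluoro in place of hydrogen on an aromatic carbon. The same fluorine already sits on compound 1, which gives 55700 nM in this assay. Among the measured compounds shown here, since no measured pair shows what this change does here, only a small step, within the usual scatter, is expected from compound 2 to compound 3 in this assay, a number no higher from compound 2 to compound 3 (the limit leaves the size open). Compound 3 is therefore estimated at 60000 nM, with a range from 30000 nM to 120000 nM, and a limit may well be all that is reported.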

Compound 3, half-maximal inhibitory concentration: 26800 nM
Compound 3: middle estimate off by 2.2-fold (0.35 log units), on the high side, outside the stated range (below it).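

Changing 4-bromophenyl to 4-bromo-2-fluorophenyl gives an at least 2.2-fold lower number from compound 2 to compound 3 (0.35 log units; beyond the scatter) in this assay, so this single fluoro on the aromatic ring moves the number beyond the usual scatter, although the effect stays weak. Compound 3 also offers a second comparison, in which methyl in place of hydrogen on an aromatic nitrogen gives a 2.1-fold lower number from compound 1 to compound 3 (0.32 log units; beyond the scatter), a step that also lies beyond the scatter. The true size of the fluoro step remains unknown because the value of compound 2 is a limit of the assay: the limit of > 60000 nM in this assay, at which 1 of the 3 values shown sits.

The compounds shown leave open whether a chloro or a methoxy group at this same place would change the number as fluoro does. They also give no reason for either step.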